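A few compounds are considered here, and "the series" means these few. Any claim that something is new, unique, unknown or untested is made for them only; others in the source may bear on it.

Compound 1, `Nc1scc(CN2CCN(c3cccc(Cl)c3Cl)CC2)c1C(=O)c1ccc(Cl)cc1`: 1%
Compound 2, `Nc1scc(CN2CCN(c3cccnc3)CC2)c1C(=O)c1ccc(Cl)cc1`: 3.2%
Compound 3, `Nc1scc(CN2CCN(c3c(F)cccc3F)CC2)c1C(=O)c1ccc(Cl)cc1`: -12%

All three share one core and differ only in the aromatic group on an amine nitrogen in a ring. In a functional assay on CHO cells with adenosine receptor A1 (Homo sapiens) as the target, read by cAMP accumulation and immunoassay, with a stated time of 6 min, tested at 0.01 uM (on this read-out lower numbers stand for a stronger effect and higher numbers for a weaker effect at the one concentration tested), compound 3 stands lowest of the three: the step of a number 13 percentage points lower from compound 1 to compound 3 (beyond the scatter) and the step of a number 15.2 percentage points lower from compound 2 to compound 3 (beyond the scatter) both go beyond the scatter, whereas a number 2.2 percentage points higher from compound 1 to compound 2 (within the scatter) stays within it. Compound 4, `Nc1scc(CN2CCN(c3ccccc3Cl)CC2)c1C(=O)c1ccc(Cl)cc1`, has not been measured; it carries 2-chlorophenyl in place of 2,6-difluorophenyl on an amine nitrogen in a ring. The two steps that end at compound 3 bear on this change, since each moved onto the 2,6-difluorophenyl group and lowered the number by a modest amount. Leaving that group for a 2-chlorophenyl group is therefore expected to raise the number modestly, a number 10 percentage points higher from compound 3 to compound 4 (within the scatter). Compound 4 is accordingly estimated at -2%, within -18% to 14%.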

Compound 4, a percentage reported as activity, at one concentration (the size of the read-out at that concentration, not a potency): -2.1%
For compound 4 the middle estimate is 0.1 percentage points above the measured one, and the stated range covers the measured number.
By their numbers in this assay, from the lowest: compounds 3, 4, 1 and 2 (each within the scatter of the next, the first and the last beyond it).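

In this assay the 2-chlorophenyl group cannot be told apart from any of the other three groups: the reading lies a number 9.9 percentage points higher from compound 3 to compound 4 (within the scatter) and a number 5.3 percentage points lower from compound 2 to compound 4 (within the scatter) and also a number 3.1 percentage points lower from compound 1 to compound 4 (within the scatter) in a step that removes one chloro group. Compound 3 thus remains separated beyond the scatter only from compounds 1 and 2, while compound 4 is separated from none. Nothing measured here explains these readings. The compounds shown leave open how a methoxy group or an amine on this aromatic ring would read.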